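The source may hold more compounds than are shown below. What is called first, only, known or untested is meant among the compounds shown, and "the series" means these compounds.

Working notes on the series. Of the compounds shown here, two sharing a piperazine acetamide core have been measured so far. Compound 1 `Cc1cc(Cl)ccc1N1CCN(C(=O)COCc2ccncc2)CC1` gives 240 nM in a functional assay on HEK293 cells for positive allosteric modulation of metabotropic glutamate receptor 5 (Homo sapiens), read by FLIPR and calcium flux; a lower number here means that less compound is needed, a higher number that more compound is needed for the effect. Compound 2 `O=C(COCc1cccnc1)N1CCN(c2ccc(Cl)cc2Cl)CC1` gives 1090 nM in this assay, which is the highest of the two numbers recorded; compound 1 sits at a lower number, and the gap between the two values lies beyond the usual scatter. Going by the values given here, compound 1 and compound 2 differ in more than one place, so no single step between them can be read from these two values.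

Compound 3 `O=C(COCc1cscn1)N1CCN(c2ccc(Cl)cc2Cl)CC1` is the next compound to be measured in this assay. It keeps the core and the dichlorophenyl piperazine of compound 2 and changes only the heteroaryl at the far end of the ether: 1,3-thiazol-4-yl in place of pyridin-3-yl on a saturated chain carbon bound to an oxygen on a saturated carbon. Among the compounds with values here, nothing measured so far shows how a change at this position moves the number, so no direction can be read from the data. The expectation is a step from compound 2 to compound 3 of a 1.1-fold lower number from compound 2 to compound 3 (0.04 log units; within the scatter), which is no change beyond the scatter. Compound 3 is accordingly estimated at 1000 nM, with a range from 350 nM to 3000 nM.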

Compound 3, half-maximal effective concentration: 290 nM
Compound 3: the middle estimate sits 3.4-fold (0.54 log units) above what was measured; measured number outside the range, below it.
By their numbers in this assay, from the lowest: compounds 1 and 3 (each within the scatter of the next); then compound 2.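

In this assay the heteroaryl at the far end of the ether proves able to move the number, with a 3.8-fold lower number from compound 2 to compound 3 (0.58 log units; beyond the scatter) on placing 1,3-thiazol-4-yl in place of pyridin-3-yl on a saturated chain carbon bound to an oxygen on a saturated carbon. Going by these compounds alone, this is the first step that can be read at a single place, and it shows that this position matters while the rest of compound 2 stays unchanged. The change swaps a six-membered aromatic ring with 1 hetero atom and 1 hydrogen-bond acceptor for a five-membered aromatic ring with 2 hetero atoms and 2 hydrogen-bond acceptors, and no available evidence assigns the step to any one of these differences.

Within the data shown here, compound 1 differs from both compound 2 and compound 3 in more than one place, so no step involving it can be read, and whether the gain from 1,3-thiazol-4-yl carries over to other aryl groups on the piperazine stays open. Also open, as far as these compounds go, is how a plain phenyl ring, a 1,3-thiazol-2-yl group or a longer chain between the ring and the ether oxygen would behave at this position.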